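The compounds below may be only part of what the source reports. "The series", "measured", "known", "first", "only" and "open" are said of these compounds alone.

Values in a physicochemical assay for pharmacokinetics, read by fluorescence and HPLC, with a stated time of 24 h; on this read-out higher numbers stand for a longer-lived compound and lower numbers for a shorter-lived compound:
- compound 1 `CC(C)(C)C1=C(C(=O)O)N2C(=O)/C(=C/c3ccccc3)C2O1`: 0.21 h
- compound 2 `CC(C)(C)C1=C(C(=O)O)N2C(=O)/C(=C/c3ccoc3)C2O1`: 0.32 h

For the measured compounds named here, compound 2, at 0.32 h, stands level with compound 1, the only other measured compound. Next is compound 3 `COc1cccc(/C=C2/C(=O)N3C(C(=O)O)=C(C(C)(C)C)OC23)c1`, with this change: 3-methoxyphenyl in place of furan-3-yl on a double-bonded chain carbon bound to a double-bonded ring carbon. In words, 3-methoxyphenyl takes the place of furan-3-yl on a double-bonded chain carbon bound to a double-bonded ring carbon.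

Going by the values given here, one measured step bears on this place: a 1.5-fold higher number from compound 1 to compound 2 (0.18 log units; within the scatter). It stays within the scatter. Compound 1, with phenyl there, gives 0.21 h, and that is the nearest guide to compound 3. Among the compounds with values here, no measured compound carries 3-methoxyphenyl, so the data do not cover that group. In this assay no shift beyond the scatter is expected, and any small drift would run toward compound 1.

The expected change is a 1.3-fold lower number from compound 2 to compound 3 (0.11 log units; within the scatter). For compound 3 the estimate is 0.25 h, with an expected range of 0.13 h to 0.48 h.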

Compound 3, half-life: 0.21 h
Estimate against measurement, compound 3: 1.2-fold (0.08 log units) above, within the range that was stated.
By their numbers in this assay, from the lowest: compounds 1, 3 and 2 (each within the scatter of the next).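

In this assay, the chain-carbon position now carries a third aromatic group, and the step of a 1.5-fold lower number from compound 2 to compound 3 (0.18 log units; within the scatter) stays within the scatter, as does the step of no change at the digits printed from compound 1 to compound 3 (within the scatter) on adding methoxy to an aromatic carbon. Across phenyl, furan-3-yl and 3-methoxyphenyl on a double-bonded chain carbon bound to a double-bonded ring carbon, the half-life therefore shows no separation, whether the group is a five-membered aromatic ring with 1 hetero atom or a six-membered aromatic ring of carbon only. Nothing available gives a reason for this flat result.

On these data alone, whether an amine, a carboxylic acid or a longer chain in this place would move the half-life beyond the scatter stays open. As far as these compounds go, the three compounds also share the same core, so the effect of changes elsewhere on it is unknown.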